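Dropping the Hydroxyl and Methyl from a Hydrazone Core

The source may hold more compounds than are shown below. What is called first, only, known or untested is meant among the compounds shown, and "the series" means these compounds.

Measured compounds:
- Compound 1 `CCCSc1nc(N/N=C(\C)c2ccc(O)cc2)c2nnn(Cc3ccccc3)c2n1`: 16700 nM
- Compound 2 `C#CCSc1nc(N/N=C/c2cc(OC)c(OC)c(OC)c2)c2nnn(Cc3ccccc3)c2n1`: 4670 nM
- Compound 3 `CCCSc1nc(N/N=C(\C)c2ccccc2O)c2nnn(Cc3cccc(Cl)c3)c2n1`: 6500 nM

All three were tested in a functional assay on MGC-803 cells (Homo sapiens) for antiproliferative activity, read by MTT assay, with a stated time of 72 h; a lower number here means a stronger inhibitor, a higher number a weaker inhibitor. Among them compound 1 gives the highest number, so it is the weakest inhibitor of the set: compound 3 sits nearer to it, and compound 2 sits furthest from it, both with numbers beyond the usual scatter. No pair of these compounds differs in only one place, so no single change can yet be tied to a change in the readings.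

Compound 4 `CCCSc1nc(N/N=C/c2ccccc2)c2nnn(Cc3ccccc3)c2n1` has not been measured. Compared with compound 1, it carries a group of 8 heavy atoms (7 carbon, 1 nitrogen; one six-membered aromatic ring of carbon only) in place of a group of 10 heavy atoms (8 carbon, 1 nitrogen, 1 oxygen; one six-membered aromatic ring of carbon only), on a nitrogen on an aromatic ring. The group that leaves carries an oxygen and a hydrogen-bond donor; the group that enters has no donor.

Among the compounds with values here, since nothing among the measured compounds isolates this change, the expectation rests only on the spread of the three numbers. The step of a 1.5-fold lower number from compound 1 to compound 4 (0.18 log units; within the scatter) is expected to be small and to lie within the scatter, leaning towards a slightly lower number. Compound 4 is therefore estimated at 11000 nM, within a range from 4000 nM to 30000 nM.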

Compound 4, half-maximal inhibitory concentration: > 64000 nM
Compound 4: a limit, no number; the forecaster's own chance of this, stated with the estimate: 10%; at least 5.8-fold (0.76 log units) between middle value and limit.
By their numbers in this assay, from the lowest: compounds 2 and 3 (each within the scatter of the next); then compound 1. At a limit, above all of these: compound 4.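

In this assay compound 4 gives a limit and not a number, > 64000 nM. Within the data shown here, this is the first comparison in the set where the compounds differ in only one place, and it reads as an at least 3.8-fold higher number from compound 1 to compound 4 (0.58 log units; beyond the scatter), so the group on a nitrogen on an aromatic ring clearly matters: replacing the larger group, with its oxygen and hydrogen-bond donor, by the smaller group with no donor weakens the compound instead of leaving it unchanged. The printed size of this step is only a minimum, as it rests on a limit: the limit of > 64000 nM in this assay, at which 1 of the 4 values shown sits.

Both the hydroxyl and the methyl leave in this single change, so the compounds shown cannot tell whether the loss follows one of them alone or the two together. They also leave open how an amine or a carboxylic acid in place of the hydroxyl would read, and whether the same change would have a similar effect with the other groups carried by compound 2 or compound 3.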